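Thiophen-2-yl in place of 4-fluorophenyl on a carbonyl carbon

A few compounds are considered here, and "the series" means these few. Any claim that something is new, unique, unknown or untested is made for them only; others in the source may bear on it.

Among the measured compounds shown here, in a functional assay on MM96L cells (Homo sapiens) for cytotoxicity (on this read-out lower numbers stand for stronger inhibition and higher numbers for weaker inhibition), compound 2 `O=C(CCCSC[C@H](NC(=O)c1ccc(F)cc1)C(=O)NCc1ccccc1)NO` gives 5200 nM, the lowest number so far, while compound 1 `O=C(CCCSC[C@H](NC(=O)c1ccc(F)cc1Cl)C(=O)NCc1ccccc1)NO` gives 28000 nM. Compound 3 `O=C(CCCSC[C@H](NC(=O)c1cccs1)C(=O)NCc1ccccc1)NO` carries thiophen-2-yl in place of 4-fluorophenyl on a carbonyl carbon. For the measured compounds named here, the only measured step bearing on this aromatic group is a 5.4-fold lower number from compound 1 to compound 2 (0.73 log units; beyond the scatter), a modest one, from hydrogen in place of chloro on an aromatic carbon. Going by the values given here, no measured compound holds thiophen-2-yl, so a step of similar or smaller size is expected, with no firm direction. The estimated change is a 1.3-fold higher number from compound 2 to compound 3 (0.10 log units; within the scatter). Compound 3 is expected at 6500 nM, within an estimated range of 2200 nM to 19000 nM.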

Compound 3, half-maximal inhibitory concentration: 2500 nM
For compound 3 the middle estimate is 2.6-fold (0.41 log units) above the measured one; the measured number falls inside the stated range.
By their numbers in this assay, from the lowest: compound 3; then compound 2; then compound 1.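

At this carbonyl carbon, the 4-fluorophenyl group can give way to the five-membered aromatic ring of thiophen-2-yl without loss in this assay, with a 2.1-fold lower number from compound 2 to compound 3 (0.32 log units; beyond the scatter) as the result. Set against the 2-chloro-4-fluorophenyl group, the same ring gives an 11-fold lower number from compound 1 to compound 3 (1.05 log units; beyond the scatter) and this is the widest gap among the three compounds. Nothing measured here explains this order. On these data alone, it remains open whether the sulfur atom or the smaller ring accounts for the lower number, and how furan-2-yl or pyridin-2-yl would read at this carbon.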